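The source may hold more compounds than are shown below. What is called first, only, known or untested is meant among the compounds shown, and "the series" means these compounds.

Of the compounds shown here, two have so far been measured in a functional assay on isolated protein for agonist activity at Glucose-dependent insulinotropic receptor (Homo sapiens), read by HTRF and cAMP accumulation; on this read-out lower numbers stand for an effect already at smaller amounts and higher numbers for an effect only at larger amounts of compound. Compound 2 `CC1(OC(=O)N2CCC(O[C@H]3CC[C@H](Oc4cnc(S(C)(=O)=O)cn4)CC3)CC2)CC1` gives 25.9 nM, the lowest of the two numbers. Among the compounds with values here, its nearest neighbour, compound 1 `CC(C)(C)OC(=O)N1CCC(O[C@H]2CC[C@H](Oc3ccc(S(C)(=O)=O)nn3)CC2)CC1`, gives 651 nM in this assay, a gap that lies beyond the usual scatter; compound 1 differs from compound 2 in more than one place, so no single step connects the two.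

Compound 3 `CS(=O)(=O)c1cnc(O[C@H]2CC[C@H](OC3CCN(C(=O)Oc4ccccc4)CC3)CC2)cn1` has not yet been measured. It differs from compound 2 in one place only: phenyl in place of 1-methylcyclopropyl on an oxygen next to a carbonyl group. Within the data shown here, no pair of measured compounds shows this change, so nothing in the present data tells how large its effect is or which way it goes. Among the measured compounds shown here, the only anchor is compound 2, whose number stands as the starting point. The expected step is modest, most likely toward a higher number, and may well stay within the scatter: a 2.3-fold higher number from compound 2 to compound 3 (0.36 log units; beyond the scatter). Compound 3 is therefore estimated to give 60 nM in this assay, with a range from 15 nM to 250 nM.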

Compound 3, half-maximal effective concentration: 9.6 nM
For compound 3 the middle estimate is 6.3-fold (0.80 log units) above the measured one; the measured number lies below the stated range.
By their numbers in this assay, from the lowest: compound 3; then compound 2; then compound 1.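

In this assay, within the data shown here, the exchange of 1-methylcyclopropyl for phenyl on an oxygen next to a carbonyl group gives a 2.7-fold lower number from compound 2 to compound 3 (0.43 log units; beyond the scatter) and is the first single change that can be read. It shows that this place accepts a six-membered aromatic ring of carbon only, a group with more heavy atoms than the one it replaces, and that the three-membered non-aromatic ring is not needed here for a number this low. The compounds shown offer no measurement that accounts for the direction or size of this step.

From the compounds shown here alone, what remains open is how far this place can be varied beyond these two groups, for instance whether a phenyl ring carrying a chlorine or a methoxy group, a benzyl group or a cyclohexyl group would carry the trend further or reverse it. Among these compounds, it is equally open whether phenyl would give a step of the same size and direction on a different core, as this single pair is the only comparison available.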